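Oxime ether series: methoxy to ethoxy

The source may report more compounds than this note shows. Statements on the series, on what has been measured and on what is new or still open speak of the compounds shown alone.

Measured compounds:
compound 1, `c1ccc(-c2cnco2)c(NCC2=NCCN2)c1`, 17.4 nM
compound 2, `CO/N=C(\C)c1ccccc1NCC1=NCCN1`, 20.9 nM

Compound 1 and compound 2 share a core and differ on one aromatic carbon. In a functional assay for activation of Alpha-1A adrenergic receptor (Homo sapiens), read by calcium flux (on this read-out lower numbers stand for an effect already at smaller amounts and higher numbers for an effect only at larger amounts of compound), compound 1 gives 17.4 nM and compound 2 gives 20.9 nM; the step of a 1.2-fold higher number from compound 1 to compound 2 (0.08 log units; within the scatter) is within the scatter, so the two compounds are not separated by the numbers shown. Among the measured compounds shown here, compound 2 holds the highest of the two numbers, with compound 1 as its only neighbour at a step that the scatter covers.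

Compound 3, `CCO/N=C(\C)c1ccccc1NCC1=NCCN1`, has not been measured in this assay. It differs from compound 2 by methyl in place of hydrogen on a saturated chain carbon bound to an oxygen on an unsaturated carbon. For the measured compounds named here, the only measured step, the exchange between compound 1 and compound 2 that changed a group of the same atom count, left this assay unchanged beyond the scatter. Going by the values given here, no step shows what lengthening the chain on the oxime oxygen does, so the expectation rests on that single neighbouring step and the small size of the change. The expected step is a 1.1-fold higher number from compound 2 to compound 3 (0.06 log units; within the scatter), that is, none beyond the scatter.

Compound 3 is estimated at 24 nM, within 8 nM to 75 nM in this assay.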

Compound 3, half-maximal effective concentration: 52.5 nM
Compound 3: middle estimate off by 2.2-fold (0.34 log units), on the low side; the range from low to high includes it.
By their numbers in this assay, from the lowest: compounds 1 and 2 (each within the scatter of the next); then compound 3.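

Going from methoxy to ethoxy gives a 2.5-fold higher number from compound 2 to compound 3 (0.40 log units; beyond the scatter) in this assay and shows that this saturated chain carbon bound to an oxygen on an unsaturated carbon is sensitive to a single added methyl, which the earlier exchange on the aromatic carbon could not show. Compound 1 and compound 2 could not be separated, but the ethoxy oxime ether of compound 3 is separated from compound 1 by a 3.0-fold higher number from compound 1 to compound 3 (0.48 log units; beyond the scatter) and so not every open-chain group on that aromatic carbon matches the ring-bearing group of compound 1. No measurement shown here bears on what lies behind the step from methoxy to ethoxy.

Among the compounds shown here, whether the number keeps climbing with a longer chain such as propoxy or butoxy, or with a branched isopropoxy group, remains open, since a single pair of oxime ethers fixes only one step and no trend along the chain. Also open, on these data alone, is how a free hydroxyl on the oxime oxygen would compare with methoxy in this assay and whether the step from methoxy to ethoxy would carry over to other read-outs.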